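Nitro to Hydroxy on the Terminal Aryl Ring

This account rests on a few compounds, and the source may have more. Where it says the series, first, only, none or still open, it means among the compounds named here.

Of the compounds shown here, three sharing one core have been tested in a functional assay on MCF7 cells (Homo sapiens) for cytotoxicity, read by MTT assay, with a stated time of 72 h; on this read-out lower numbers stand for stronger inhibition and higher numbers for weaker inhibition. Compound 1 `O=C(N/N=C/c1ccc([N+](=O)[O-])cc1)Nc1cc2c(Nc3ccc(F)c(Cl)c3)ncnc2cc1O[C@H]1CCOC1` was reported as "not active" (no number reported). Compound 2 `O=C(N/N=C/c1ccc(O)c(Br)c1)Nc1cc2c(Nc3ccc(F)c(Cl)c3)ncnc2cc1O[C@H]1CCOC1` gives 2690 nM. Compound 3 `COc1cc2ncnc(Nc3ccc(F)c(Cl)c3)c2cc1NC(=O)N/N=C/c1ccc([N+](=O)[O-])cc1` gives 36800 nM, the highest of the two numbers and well beyond the scatter from compound 2. Compound 4 `COc1cc2ncnc(Nc3ccc(F)c(Cl)c3)c2cc1NC(=O)N/N=C/c1ccc(O)cc1` has not yet been measured; it differs from compound 3 by hydroxy in place of nitro on an aromatic carbon. Among the compounds with values here, compounds 1 and 2 differ in more than one place, so their values show only that the nitro-bearing compound 1 returned no number while compound 2, carrying a hydroxy, did. On that basis a step toward a lower number is expected for compound 4, a 4.1-fold lower number from compound 3 to compound 4 (0.61 log units; beyond the scatter), beyond the scatter. Compound 4 is estimated at 9000 nM, within 2500 nM to 35000 nM.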

Compound 4, half-maximal inhibitory concentration: 28600 nM
For compound 4 the middle estimate is 3.2-fold (0.50 log units) below the measured one; the range from low to high includes it.
By their numbers in this assay, from the lowest: compound 2; then compounds 4 and 3 (each within the scatter of the next).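

In this assay, within the data shown here, replacing 4-nitrophenyl with 4-hydroxyphenyl gives a 1.3-fold lower number from compound 3 to compound 4 (0.11 log units; within the scatter) and offers the first one-place reading of this change. At this position, on this core, the swap therefore does not separate the two compounds, even though three heavy atoms leave and one enters. No supporting measurement is available to explain this outcome. On these data alone, whether an amine or a carboxylic acid at this place would give a different number remains open. So does whether the same swap would read alike on the core of compound 1.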